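This account rests on a few compounds, and the source may have more. Where it says the series, first, only, none or still open, it means among the compounds named here.

Measured so far:
compound 1 `O=C1c2ccccc2CN1c1cnc(NCc2c(F)ccc3c2CCO3)n2cnnc12` — 2.7
compound 2 `CNC(=O)c1ncc(-c2cnc(NCc3c(F)ccc4c3CCO4)c3cn[nH]c(=O)c23)n1C` — 2.5
compound 3 `CNC(=O)c1ccc(-c2cnc(NCc3c(F)ccc4c3CCO4)c3cn[nH]c(=O)c23)c(C)n1` — 2.9

In a physicochemical assay for lipophilicity, using the shake flask method, in phosphate buffer, measured as octanol-water partition, with a stated time of 30 min, at pH 7.4 (on this read-out lower numbers stand for lower lipophilicity and higher numbers for higher lipophilicity), compound 1 gives 2.7, the second highest of the three numbers; compound 3 sits nearest with 2.9 and compound 2 furthest with 2.5, both within the scatter of compound 1, so the three measured compounds are not separated on this read-out.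

Among the compounds with values here, the only step between measured compounds that differ in one place, a number 0.40 log units higher from compound 2 to compound 3 (beyond the scatter), concerns an exchange of aromatic substituents on a different core and touches neither the group that leaves nor the group that enters here. It therefore gives no direct guidance.

Compound 4 `Fc1ccc2c(c1CNc1ncc(Nc3ccccc3)c3nncn13)CCO2` differs from compound 1 in one place: a group of 7 heavy atoms (6 carbon, 1 nitrogen; one six-membered aromatic ring of carbon only) in place of a group of 10 heavy atoms (8 carbon, 1 nitrogen, 1 oxygen; one five-membered non-aromatic ring with 1 hetero atom, one six-membered aromatic ring of carbon only), on an aromatic carbon. The leaving group carries a carbonyl and a non-aromatic ring; the entering group is smaller and brings one hydrogen-bond donor. Within the data shown here, no measured pair covers this exchange, so the expectation rests on compound 1 alone, with a wide range.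

For compound 4 a value of 3 is expected in this assay, between 2.4 and 3.6, which would mean a step of a number 0.30 log units higher from compound 1 to compound 4 (within the scatter) from compound 1, judged as likely within or only just beyond the scatter.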

Compound 4, distribution coefficient: 3.3
Compound 4: the middle estimate sits 0.30 log units below what was measured, and the stated range covers the measured number.
By their numbers in this assay, from the lowest: compounds 2, 1 and 3 (each within the scatter of the next, the first and the last beyond it); then compound 4.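

In this assay, within the data shown here, anilino in place of the group of 10 heavy atoms, on an aromatic carbon, gives a number 0.60 log units higher from compound 1 to compound 4 (beyond the scatter), so this read-out does respond to an exchange at this position, which the earlier compounds could not show. The entering group is the smaller of the two by heavy atoms and has 1 hydrogen-bond donor where the leaving group has 0, so neither a lower heavy-atom count nor the added donor came with a lower number in this one pair. No measurement available here accounts for the step.

This single pair changes the carbonyl, the five-membered non-aromatic ring, the heavy-atom count and the hydrogen-bond donor count together, so the contribution of each stays unresolved. From the compounds shown here alone, it remains open how the number would move with N-methylanilino, which lacks the amine hydrogen, with morpholine, or with a carboxylic acid at the same position, and whether the step would carry over to another core.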